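A Larger Side Group on a Core Without a Reading

The source may report more compounds than this note shows. Statements on the series, on what has been measured and on what is new or still open speak of the compounds shown alone.

Compound 1 `O=c1cc(Cn2cc(CCCO)nn2)c2ccc(O)cc2o1` gives in a functional assay on CFPAC-1 cells (Homo sapiens) for inhibition, read by MTT assay, with a stated time of 72 h (a higher number here means a weaker inhibitor, a lower number a stronger inhibitor), the limit > 100000 nM. Compound 2 `CC(C)(C)c1cn(Cc2cc(=O)oc3cc(O)ccc23)nn1` gives in this assay the limit > 100000 nM.

Compound 1 thus stands only at a limit, not at a number. The step from compound 1 to compound 2 is a step that the two limits leave unreadable from compound 1 to compound 2, unreadable because of the limit of > 100000 nM in this assay, at which 2 of the 2 values shown sit. Compound 3 `O=c1cc(Cn2cc(CSC(=S)N3CCOCC3)nn2)c2ccc(O)cc2o1` differs from compound 1 by a group of 9 heavy atoms (5 carbon, 1 nitrogen, 1 oxygen, 2 sulfur; one six-membered non-aromatic ring with 2 hetero atoms) in place of a group of 3 heavy atoms (2 carbon, 1 oxygen; no ring), on a saturated chain carbon bound to an aromatic carbon. Within the data shown here, no measured step shows how such a group acts in this assay. Compound 3 is therefore expected to give 100000 nM, between 20000 nM and 300000 nM. The expected step of a number no higher from compound 1 to compound 3 (the limit leaves the size open) is estimated to stay within the scatter.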

Compound 3, half-maximal inhibitory concentration: 56300 nM
Compound 3: middle estimate off by 1.8-fold (0.25 log units), on the high side; measured number inside the range.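

Among these compounds, with the group of 9 heavy atoms on the saturated chain carbon bound to an aromatic carbon, compound 3 gives a number in this assay, whereas the earlier compounds gave only limits. The change is an at least 1.7-fold lower number from compound 1 to compound 3 (0.24 log units; that floor lies within the scatter). The full size of this step stays open because the value of compound 1 is a limit, not a number: the limit of > 100000 nM in this assay, at which 2 of the 3 values shown sit.

Going by these compounds, whether the ring or the sulfur atoms of the entering group matter more remains open. So does how an amine or a carboxylic acid would read at this place.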